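The source may hold more compounds than are shown below. What is called first, only, known or untested is meant among the compounds shown, and "the series" means these compounds.

Measured so far in a functional assay on CHO cells for agonist activity at Melanocortin receptor 4 (Homo sapiens), read by a luciferase reporter, with a stated time of 4 h; a lower number here means that less compound is needed, a higher number that more compound is needed for the effect:
- compound 1 `COc1ccc(N(C(=O)CN2C=CN(c3ccccc3)C(=O)C(Cc3n[nH]c4ccccc34)C2=O)C(C)C)cc1`: 708 nM
- compound 2 `CC(C)N(C(=O)CN1C=CN(c2ccccc2)C(=O)C(Cc2n[nH]c3ccccc23)C1=O)c1ccc(O)cc1`: 1000 nM; 1000 nM; 31600 nM; > 30000 nM (4 entries)

Among the measured compounds shown here, compound 1 holds the only single value in this assay. The entries of compound 2 scatter widely, and the last of them is a limit of the assay and not a number (the several entries of compound 2 in this assay, 1000 nM; 1000 nM; 31600 nM; > 30000 nM (4 entries)). For the measured compounds named here, no step between measured compounds exists, so nothing anchors the size of a ring substitution here.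

Compound 3 `COc1ccc(N(C(=O)CN2C=CN(c3ccccc3)C(=O)C(Cc3n[nH]c4cc(F)ccc34)C2=O)C(C)C)cc1` differs from compound 1 by fluoro in place of hydrogen on an aromatic carbon. No change beyond the scatter is expected from compound 1 to compound 3 in this assay, a 1.2-fold lower number from compound 1 to compound 3 (0.07 log units; within the scatter). Compound 3 is estimated at 600 nM, within 250 nM to 1800 nM.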

Compound 3, half-maximal effective concentration: 355 nM
Compound 3: the middle estimate sits 1.7-fold (0.23 log units) above what was measured, within the range that was stated.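

This gives the series its first readable step: with fluoro in place of hydrogen on an aromatic carbon of the six-membered aromatic ring of carbon only, this assay shows a 2.0-fold lower number from compound 1 to compound 3 (0.30 log units; within the scatter). The position therefore accepts this single fluorine without a change beyond the scatter. Repeated entries spread widely elsewhere in the series, and one of them is a limit of the assay and not a number: the several entries of compound 2 in this assay, 1000 nM; 1000 nM; 31600 nM; > 30000 nM (4 entries)

Open, on these data alone, is whether an amine or a carboxylic acid at this carbon would move the number beyond the scatter. The shown compounds also leave open how fluoro behaves on the other ring carbons.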